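Swapping methoxy for chloro on a cinnamamide

The source may hold more compounds than are shown below. What is called first, only, known or untested is meant among the compounds shown, and "the series" means these compounds.

Of the compounds shown here, two from this study have been measured in an assay on mitochondria (strain Sprague-Dawley) for inhibition of Amine oxidase [flavin-containing] B (Rattus norvegicus), read by fluorescence and Amplex Red, with stated times of 30 min and 45 min; a higher number here means a weaker inhibitor, a lower number a stronger inhibitor. Compound 1 `COc1cccc(/C=C/C(=O)Nc2nc3ccccc3c(=O)s2)c1` gives 281 nM in this assay. Compound 2 `COc1cccc(/C=C/CC(=O)Nc2nc3ccccc3c(=O)s2)c1` gives 2020 nM in this assay. Compound 1 therefore carries the lower of the two numbers, and the gap between it and compound 2 lies beyond the usual scatter of repeated measurements.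

Among the compounds with values here, the next compound keeps the whole framework of compound 1 and changes only one group on its outer ring. Compound 3 `O=C(/C=C/c1cccc(Cl)c1)Nc1nc2ccccc2c(=O)s1` differs from compound 1 as follows: chloro in place of methoxy on an aromatic carbon. Within the data shown here, since no pair of measured compounds shows this kind of change, there is no measured step to lean on; the expectation rests only on the value of compound 1 and on the small size of the change.

For that reason the step expected from compound 1 to compound 3 is a 1.4-fold lower number from compound 1 to compound 3 (0.15 log units; within the scatter), a shift toward a slightly lower number that may still fall within the scatter. Compound 3 is estimated at 200 nM in this assay, with a likely range from 60 nM to 700 nM.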

Compound 3, half-maximal inhibitory concentration: 815 nM
Estimate against measurement, compound 3: 4.1-fold (0.61 log units) below; the whole stated range lies below it.
By their numbers in this assay, from the lowest: compound 1; then compound 3; then compound 2.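

In this assay, going from 3-methoxyphenyl to 3-chlorophenyl gives a 2.9-fold higher number from compound 1 to compound 3 (0.46 log units; beyond the scatter), so this position on the outer ring is sensitive to which group it carries, even when the rest of the molecule stays the same. The exchange is small on paper: methoxy, with two heavy atoms and one hydrogen-bond acceptor, gives way to chloro, with one heavy atom and no acceptor, yet the step lies beyond the usual scatter and favours methoxy in this pair. Nothing available here accounts for the change, so the reason for it remains unknown.

With only methoxy and chloro to compare at this position, a single step cannot show which feature of the group matters, and a hydroxyl, a methyl, a fluoro or an amine there would give further points of comparison. As far as these compounds go, it also remains open whether the same swap would give a step of similar size on the longer chain of compound 2, or whether an ethoxy group would do better or worse than methoxy on the chain of compound 1.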